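Phenyl for butyl on the ring nitrogen of compound 1

A few compounds are considered here, and "the series" means these few. Any claim that something is new, unique, unknown or untested is made for them only; others in the source may bear on it.

Compound 1 `CCCCn1ncc(OCc2nnc(-c3ccccc3)o2)c(Cl)c1=O` stands only at a limit in a functional assay on the whole organism for inhibition, with Mythimna separata as the target, with a stated time of 5 days; on this read-out lower numbers stand for an effect already at smaller amounts and higher numbers for an effect only at larger amounts of compound: compound 1 gives > 300 ug/mL, which is the limit of > 300 ug/mL in this assay, at which 1 of the 2 values shown sits. Compound 2 `CCCCn1ncc(OCc2nnc(-c3ccc(F)cc3)o2)c(Cl)c1=O` gives 162 ug/mL in this assay, and the step of an at least 1.8-fold lower number from compound 1 to compound 2 (0.26 log units; that floor lies within the scatter) concerns fluoro in place of hydrogen on an aromatic carbon. Compound 3 `O=c1c(Cl)c(OCc2nnc(-c3ccccc3)o2)cnn1-c1ccccc1` carries phenyl in place of butyl on an aromatic nitrogen. Among the compounds with values here, no measured step touches this position, and the single measured step sits within the scatter, so no change beyond the scatter is expected from the phenyl. Compound 3 is therefore estimated at 300 ug/mL, between 100 ug/mL and 600 ug/mL, an expected step of a number no higher from compound 1 to compound 3 (the limit leaves the size open), with a real chance that only a limit is again reported.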

Compound 3, half-maximal effective concentration: 91.5 ug/mL
Estimate against measurement, compound 3: 3.3-fold (0.52 log units) above, and the stated range ends above it.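

In this assay, the substituent on the ring nitrogen matters: phenyl in place of butyl gives an at least 3.2-fold lower number from compound 1 to compound 3 (0.51 log units; beyond the scatter). Within the data shown here, this is the first step beyond the scatter, as the only earlier step, fluoro on an aromatic carbon, stays within it. The size of the step remains open, because the value of compound 1 is a limit: the limit of > 300 ug/mL in this assay, at which 1 of the 3 values shown sits.

Going by these compounds, whether the aromatic ring itself matters, rather than the group's size, remains open; cyclohexyl or benzyl on this nitrogen would address that. Also open, on these data alone, is how phenyl here combines with fluoro.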